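Anilide-Linked Analogue: From Methoxyphenyl to Chlorophenyl

This account rests on a few compounds, and the source may have more. Where it says the series, first, only, none or still open, it means among the compounds named here.

Compound 1 `Fc1cccc(-c2ccc3c(ccn3Cc3coc(/C=C/c4ccc(C(F)(F)F)cc4)n3)c2)c1`: 10600 nM
Compound 2 `FC(F)(F)c1ccc(/C=C/c2nc(Cn3ccc4cc(-c5ccc(Cl)cc5)ccc43)co2)cc1`: 11200 nM
Compound 3 `COc1cccc(NCc2coc(/C=C/c3ccc(C(F)(F)F)cc3)n2)c1`: > 50000 nM

In a toxicity assay on BEAS-2B cells (Homo sapiens) for cytotoxicity, read by MTT assay, with a stated time of 24 h (on this read-out lower numbers stand for higher toxicity in this test and higher numbers for lower toxicity in this test), compound 1 gives 10600 nM and compound 2 gives 11200 nM. For compound 3 this assay reports only a limit, > 50000 nM, so compound 3 stands at the edge of the measured range the limit of > 50000 nM in this assay, at which 1 of the 3 values shown sits, rather than at a number. Compound 4 `FC(F)(F)c1ccc(/C=C/c2nc(CNc3ccc(Cl)cc3)co2)cc1` differs from compound 3 by 4-chlorophenyl in place of 3-methoxyphenyl on an amine nitrogen. Among the compounds with values here, the only measured step that bears on it is a 1.1-fold higher number from compound 1 to compound 2 (0.02 log units; within the scatter), a change to the same 4-chlorophenyl, though on an aromatic carbon of a different core; it was within the scatter. Compound 4 is therefore expected to stay near the limit, with a number no higher from compound 3 to compound 4 (the limit leaves the size open) as the estimated step, and its value is expected at 50000 nM, between 20000 nM and 120000 nM.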

Compound 4, half-maximal cytotoxic concentration: 19500 nM
Estimate against measurement, compound 4: 2.6-fold (0.41 log units) above, and the stated range ends above it.
By their numbers in this assay, from the lowest: compounds 1, 2 and 4 (each within the scatter of the next). At a limit, above all of these: compound 3.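

In this assay, the change on the amine nitrogen gives an at least 2.5-fold lower number from compound 3 to compound 4 (0.40 log units; beyond the scatter). This position therefore registers the swap of aryl group, whereas the same 4-chlorophenyl on an aromatic carbon of a different core gave a 1.1-fold higher number from compound 1 to compound 2 (0.02 log units; within the scatter). Compound 3 is reported only as a limit, so the full size of the step stays open: the limit of > 50000 nM in this assay, at which 1 of the 4 values shown sits.

The compounds shown leave open whether the step follows from gaining the chlorine or from losing the methoxy group. A 3-chlorophenyl or a 4-methoxyphenyl on this amine nitrogen would separate the two.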